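Phenoxymethyl for benzyl on a bis-aziridinyl quinone core

A few compounds are considered here, and "the series" means these few. Any claim that something is new, unique, unknown or untested is made for them only; others in the source may bear on it.

Measured compounds:
compound 1, `CC1=C(N2CC2)C(=O)C(Cc2ccccc2)=C(N2CC2)C1=O`, 4.85
compound 2, `CC1=C(N2CC2)C(=O)C(C(C)C)=C(N2CC2)C1=O`, 5.6
compound 3, `CCCC1=C(N2CC2)C(=O)C(CCOC(N)=O)=C(N2CC2)C1=O`, 5.68

The three compounds share one core and were tested in a functional assay on L1210 cells (Mus musculus), with a stated time of 12 days; a lower number here means a less potent compound, a higher number a more potent compound, by a factor of ten per unit of this negative logarithm. Compound 1 has the lowest of the three numbers; the nearest is compound 2, which lies a number 0.75 log units higher from compound 1 to compound 2 (beyond the scatter), a step beyond the scatter. Compound 3 stands higher still, but it differs from compound 1 in more than one place, so no single step can be read from it.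

Compound 4, `CC1=C(N2CC2)C(=O)C(COc2ccccc2)=C(N2CC2)C1=O`, is not yet measured. Its change from compound 1 is phenoxy in place of phenyl on a saturated chain carbon bound to a double-bonded ring carbon. Among the measured compounds shown here, the one measured step, from compound 1 to compound 2, swaps the whole benzyl group for isopropyl and so does not mirror this change; it shows only that altering this side chain can shift the number modestly. The aromatic ring is kept, one oxygen enters. A small move upward from the low number of compound 1 seems plausible, though nothing rules out no change beyond the scatter.

The estimated step in this assay is a number 0.25 log units higher from compound 1 to compound 4 (within the scatter). Compound 4 is therefore expected to give about 5.1, within a range from 4.6 to 5.7.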

Compound 4, logarithm of the reciprocal of the active concentration, log(1/C): 5.15
The estimate for compound 4 lay 0.05 log units below the measured number, and the stated range covers the measured number.
By their numbers in this assay, from the lowest: compounds 1 and 4 (each within the scatter of the next); then compounds 2 and 3 (each within the scatter of the next).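

In this assay, the change to phenoxy in place of phenyl on a saturated chain carbon bound to a double-bonded ring carbon gives a number 0.30 log units higher from compound 1 to compound 4 (within the scatter). The aromatic ring stays and a hydrogen-bond acceptor enters the side chain, yet the result does not stand clear of the usual scatter, something the earlier swap of the whole benzyl group for isopropyl, a number 0.75 log units higher from compound 1 to compound 2 (beyond the scatter), could not show. No measurement here bears on the reason for this result.

An amine or a carboxylic acid in place of phenyl on that same saturated chain carbon, or a longer chain carrying the phenoxy group, remains untested in the compounds shown. On these data alone, whether any of these would move the number beyond the scatter stays open.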